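The compounds below may be only part of what the source reports. "The series", "measured", "known", "first", "only" and "open" are said of these compounds alone.

Compound 2, `Cn1c(-c2nc(C3CCC3)cn2CCCc2ccc(OC3CCCNCC3)cc2)cc2sccc21`, stands highest of the two numbers measured here, though its nearest neighbour lies within the scatter. In a functional assay on THP-1 cells (Homo sapiens) for inhibition, read by colony formation, with a stated time of 13 days, tested at 50 nM (on this read-out higher numbers stand for a stronger effect at the one concentration tested and lower numbers for a weaker effect), compound 2 gives 40.9%. For the measured compounds named here, the only other measured compound, compound 1, `CCc1cn(CCCc2ccc(OC3CCNCC3)cc2)c(-c2cc3sccc3n2C)n1`, gives in this assay a value of 33.3%, a number that does not separate from that of compound 2.

Compound 3, `Cn1c(-c2nc(C3CCC3)cn2CCCc2ccc(OC3CCNCC3)cc2)cc2sccc21`, has not yet been measured in this assay. It differs from compound 2 in one place: piperidin-4-yl in place of azepan-4-yl on an oxygen on an aromatic ring. Going by the values given here, no step between measured compounds of this kind has been recorded, so the expected size of the step rests only on the two values shown. Because compound 1 gives 33.3% and compound 2 gives 40.9% within the scatter of each other, the step expected for compound 3 is a number 3.9 percentage points lower from compound 2 to compound 3 (within the scatter), with no clear direction beyond the scatter. For compound 3 the estimate in this assay is 37%, within a range from 20% to 55%.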

Compound 3, a percentage reported as inhibition, at one concentration (the size of the read-out at that concentration, not a potency): 38.8%
Compound 3: the middle estimate sits 1.8 percentage points below what was measured, within the range that was stated.
By their numbers in this assay, from the lowest: compounds 1, 3 and 2 (each within the scatter of the next).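

In this assay, the group on the oxygen on an aromatic ring can be azepan-4-yl or piperidin-4-yl without a difference that separates from the scatter (a number 2.1 percentage points lower from compound 2 to compound 3 (within the scatter)). For the compounds shown here, compound 3 also gives the first single-place comparison at the aromatic carbon, where cyclobutyl in place of ethyl likewise stays within the scatter (a number 5.5 percentage points higher from compound 1 to compound 3 (within the scatter)). No independent measurement is available to explain either step.

From the compounds shown here alone, it remains open whether a smaller ring on that oxygen, such as pyrrolidin-3-yl, or an open-chain amine, such as 2-(dimethylamino)ethyl, would separate from these compounds. Going by these compounds, with a read-out at a single concentration, the potencies of compound 2 and compound 3 also remain open, as does whether a larger group than cyclobutyl, such as phenyl, on the aromatic carbon would change the picture.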